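Rearranging the bicyclic group on the urea nitrogen

A few compounds are considered here, and "the series" means these few. Any claim that something is new, unique, unknown or untested is made for them only; others in the source may bear on it.

Of the compounds shown here, three with one shared core have been measured. Compound 1 `CC1CCN(c2nc(C(F)(F)F)ccc2CNC(=O)Nc2cccc3c2ccc(=O)n3C)CC1` gives 0.57 nM in an assay on CHO cells for displacement of a labelled ligand from transient receptor potential cation channel subfamily V member 1 (Homo sapiens); a lower number here means a stronger inhibitor, a higher number a weaker inhibitor. Compound 2 `CC1CCN(c2nc(C(F)(F)F)ccc2CNC(=O)Nc2cccc3ccc(=O)[nH]c23)CC1` gives 492 nM in this assay, and compound 3 `CC1CCN(c2nc(C(F)(F)F)ccc2CNC(=O)Nc2cccc3cc[nH]c(=O)c23)CC1` gives 239 nM, the second highest of the three numbers, far from compound 1 and closest to compound 2. Going by the values given here, the only measured step that rearranges this group within itself was a 2.1-fold lower number from compound 2 to compound 3 (0.31 log units; beyond the scatter), a modest change. Compound 4 `CC1CCN(c2nc(C(F)(F)F)ccc2CNC(=O)Nc2ccc3cc[nH]c(=O)c3c2)CC1` differs from compound 3 by a group of 11 heavy atoms (9 carbon, 1 nitrogen, 1 oxygen; one six-membered aromatic ring of carbon only, one six-membered aromatic ring with 1 hetero atom) in place of a group of 11 heavy atoms (9 carbon, 1 nitrogen, 1 oxygen; one six-membered aromatic ring of carbon only, one six-membered aromatic ring with 1 hetero atom), on an amide-type nitrogen. Since that one comparable step was small, the step from compound 3 to compound 4 in this assay is expected to be small as well, close to the scatter, a 1.3-fold higher number from compound 3 to compound 4 (0.10 log units; within the scatter). For compound 4 the estimate is 300 nM, with a range from 60 nM to 1500 nM.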

Compound 4, inhibition constant: 215 nM
Beside the measured number, compound 4's estimate is 1.4-fold (0.14 log units) above it; the range from low to high includes it.
By their numbers in this assay, from the lowest: compound 1; then compounds 4 and 3 (each within the scatter of the next); then compound 2.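

With the same atoms joined differently on the amide-type nitrogen, the step in this assay is a 1.1-fold lower number from compound 3 to compound 4 (0.05 log units; within the scatter) and does not separate these two compounds. The other new step, a 2.3-fold lower number from compound 2 to compound 4 (0.36 log units; beyond the scatter), is modest, and in this set compound 1 at 0.57 nM remains far from all three rearranged compounds. Nothing measured here explains these numbers.

Open, going by these compounds, is whether an ethyl group on the ring nitrogen of compound 4, or an amine on its carbon-only ring, would move its number toward that of compound 1.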